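A few compounds are considered here, and "the series" means these few. Any claim that something is new, unique, unknown or untested is made for them only; others in the source may bear on it.

Measured so far in a functional assay on the whole organism with Mus musculus as the target; a higher number here means that more compound is needed for the effect, a lower number that less compound is needed:
- compound 1 `COc1cc2c(cc1OC)C(c1ccccc1)=NNC(=O)C2`: 9.41 mg/kg
- compound 2 `COc1cc2c(cc1OC)C(c1cccc(N)c1)=NNC(=O)C2`: 5.69 mg/kg

With only these two numbers, compound 2 cannot be told apart from compound 1. Going by the values given here, the one measured step, a 1.7-fold lower number from compound 1 to compound 2 (0.22 log units; within the scatter), lies within the scatter, the ordinary spread between repeated measurements. That step is amino in place of hydrogen on an aromatic carbon.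

Compound 3 `COc1cc2c(cc1OC)C(c1ccc(N)cc1)=NNC(=O)C2` has not been measured yet. It has the same atoms as compound 2, joined differently: 4-aminophenyl in place of 3-aminophenyl on a carbon with a double bond to nitrogen. Among the compounds with values here, no measured step tests this exact change, so the evidence is indirect. The closest guide is a 1.7-fold lower number from compound 1 to compound 2 (0.22 log units; within the scatter): adding the amino group at all gave a step within the scatter. Moving that group might matter more or less than adding it, and the data cannot say which. No shift in either direction beyond the scatter is therefore expected, and the expected step is a 1.1-fold higher number from compound 2 to compound 3 (0.02 log units; within the scatter). For compound 3 the estimate is 6 mg/kg, with an expected range from 2.8 mg/kg to 13 mg/kg.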

Compound 3, dose for half-maximal effect: 3.92 mg/kg
Beside the measured number, compound 3's estimate is 1.5-fold (0.18 log units) above it; low and high end bracket the measured number.
By their numbers in this assay, from the lowest: compounds 3, 2 and 1 (each within the scatter of the next, the first and the last beyond it).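

In this assay, moving the amino group on the carbon with a double bond to nitrogen, with 4-aminophenyl in place of 3-aminophenyl, gives a 1.5-fold lower number from compound 2 to compound 3 (0.16 log units; within the scatter), so these two placements cannot be told apart. Set against the plain phenyl group, however, the 4-aminophenyl group gives a 2.4-fold lower number from compound 1 to compound 3 (0.38 log units; beyond the scatter), the first step in this short series to pass beyond the scatter, though only modestly. An amino group on this phenyl ring can therefore go with a real, if small, fall in the dose needed, yet the addition as 3-aminophenyl stayed within the scatter, and with the two amino compounds not separated, this does not prove that placement matters.

The compounds shown leave open whether the gain belongs to the amino group itself or would also appear with another group in its place, such as a hydroxyl, a methoxy or a dimethylamino group. Nothing available gives a reason for any of these steps.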